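Amide-linked thiophene replaces aryl at the saturated ring carbon

The source may report more compounds than this note shows. Statements on the series, on what has been measured and on what is new or still open speak of the compounds shown alone.

Within the data shown here, compound 2 `Cc1nn(-c2ncnc3nc[nH]c23)c2c1C(c1ccc(OC(C)C)cc1)CC(=O)N2` gives 2700 nM in a functional assay on HEK293 cells for agonist activity at G-protein coupled receptor 39 (Homo sapiens), read by scintillation proximity assay and inositol phosphate accumulation, with a stated time of 75 min (on this read-out lower numbers stand for an effect already at smaller amounts and higher numbers for an effect only at larger amounts of compound), the highest of the two numbers so far, yet only a 1.4-fold higher number from compound 1 to compound 2 (0.13 log units; within the scatter) apart from compound 1 `Cc1cc(C)n(CCOC2CC(=O)Nc3c2c(C)nn3-c2ncnc3nc[nH]c23)n1`, which gives 2000 nM. Compound 3 `Cc1nn(-c2ncnc3nc[nH]c23)c2c1C(NC(=O)Cc1cccs1)CC(=O)N2` carries (((thiophen-2-yl)methyl)carbonyl)amino in place of 4-isopropoxyphenyl on a saturated ring carbon. Among the measured compounds shown here, the one measured step at this saturated ring carbon is a 1.4-fold higher number from compound 1 to compound 2 (0.13 log units; within the scatter); it exchanged the whole group on that carbon without moving the number beyond the scatter. For the measured compounds named here, the amide-linked group entering here has no measured counterpart, so the range is kept wide. For compound 3 a step of a 1.1-fold higher number from compound 2 to compound 3 (0.05 log units; within the scatter) is expected, nothing beyond the scatter. Compound 3 is estimated at 3000 nM, between 1000 nM and 10000 nM.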

Compound 3, half-maximal effective concentration: 244 nM
The estimate for compound 3 lay 12-fold (1.09 log units) above the measured number, and the stated range ends above it.
By their numbers in this assay, from the lowest: compound 3; then compounds 1 and 2 (each within the scatter of the next).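

In this assay, the saturated ring carbon proves sensitive to its group: (((thiophen-2-yl)methyl)carbonyl)amino in place of 4-isopropoxyphenyl gives an 11-fold lower number from compound 2 to compound 3 (1.04 log units; beyond the scatter), and the same group against the earlier ether-linked group gives an 8.2-fold lower number from compound 1 to compound 3 (0.91 log units; beyond the scatter). The earlier exchange on this carbon, a 1.4-fold higher number from compound 1 to compound 2 (0.13 log units; within the scatter), had shown no such response. Nothing measured here accounts for the gain. Still open, as far as these compounds go, is which part of the entering group carries the step, the amide hydrogen, the carbonyl or the thiophene ring. A phenyl ring in place of thiophene, or a longer chain before the ring, would help to separate these.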